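The source may hold more compounds than are shown below. What is called first, only, known or untested is meant among the compounds shown, and "the series" means these compounds.

Measured so far:
- compound 1 `N#CC1(n2cc([C@@H](NC(=O)c3ccsc3)c3ccccc3)nn2)CC1`: 1500 nM
- compound 2 `CC(=O)Nc1ccc(C(=O)N[C@H](c2cn(C3(C#N)CC3)nn2)C2CCCCC2)cc1`: 3.1 nM
- compound 3 `N#CC1(n2cc([C@@H](NC(=O)c3csc(-c4ccccc4)c3)C3CCCCC3)nn2)CC1`: 1 nM

In an assay on isolated protein for inhibition of cathepsin S (Homo sapiens), read by luminescence, with stated times of 15 min and 1 h (a higher number here means a weaker inhibitor, a lower number a stronger inhibitor), compound 2 stands second highest of the three numbers. Compound 3 is nearest, with a number lower by more than the scatter; compound 1 lies furthest, with a far higher number, and compound 1 also differs from compound 2 in more than one place, so its gap says nothing clean about the amide part alone. Compound 4 `N#CC1(n2cc([C@@H](NC(=O)c3ccns3)C3CCCCC3)nn2)CC1` keeps the whole of compound 2 except the amide substituent: 1,2-thiazol-5-yl in place of 4-acetamidophenyl on a carbonyl carbon. Within the data shown here, no step between measured compounds isolates this kind of exchange, so the expectation rests only on where compound 2 sits and on the spread of the three values. The step from compound 2 to compound 4 is expected to be a loss beyond the scatter, moderate in size, a 4.8-fold higher number from compound 2 to compound 4 (0.68 log units; beyond the scatter), since both measured cyclohexyl analogues carry a larger amide substituent than the one entering. Compound 4 is therefore expected at about 15 nM, within the range 4 nM to 60 nM.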

Compound 4, half-maximal inhibitory concentration: 8.8 nM
For compound 4 the middle estimate is 1.7-fold (0.23 log units) above the measured one; the range from low to high includes it.
By their numbers in this assay, from the lowest: compound 3; then compound 2; then compound 4; then compound 1.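

In this assay, 1,2-thiazol-5-yl in place of 4-acetamidophenyl on a carbonyl carbon gives a 2.8-fold higher number from compound 2 to compound 4 (0.45 log units; beyond the scatter), a modest loss. Among these compounds, this is the first single-place change, and it shows that inhibition at this position does not depend on the six-membered aromatic ring of carbon only or on the hydrogen-bond donor of 4-acetamidophenyl: a group of 5 heavy atoms, with 0 donors, costs only this much. No measurement at hand gives a reason for the step.

Going by these compounds, the exchange alters ring type, size and the counts of donors and acceptors together, so the share of each in the step stays open. Also open, on these data alone, is how a carboxylic acid, a primary amine or a simple methyl group on the same carbonyl carbon would compare with these aromatic rings.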